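Ester chain variation in an iridoid glycoside series

The source may report more compounds than this note shows. Statements on the series, on what has been measured and on what is new or still open speak of the compounds shown alone.

Measured compounds in a functional assay on SK-BR-3 cells (Homo sapiens) for antiproliferative activity, read by MTT assay, with a stated time of 72 h; on this read-out lower numbers stand for stronger inhibition and higher numbers for weaker inhibition:
- compound 1 `C=C(C)CCOC(=O)C[C@@H]1C(C(=O)OC)=CO[C@@H](O[C@@H]2O[C@H](COC(C)=O)[C@@H](OC(C)=O)[C@H](OC(C)=O)[C@H]2OC(C)=O)/C1=C/C`: > 15000 nM
- compound 2 `C/C=C1/[C@H](O[C@@H]2O[C@H](CO)[C@@H](O)[C@H](O)[C@H]2O)OC=C(C(=O)OC)[C@H]1CC(=O)OCc1ccc2c(c1)OCCO2`: > 15000 nM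
- compound 3 `C/C=C1/[C@H](O[C@@H]2O[C@H](COC(C)=O)[C@@H](OC(C)=O)[C@H](OC(C)=O)[C@H]2OC(C)=O)OC=C(C(=O)OC)[C@H]1CC(=O)OCCC(C)C`: > 15000 nM

Compound 2 gives only a limit in this assay, > 15000 nM, not a number. The two other values shown are likewise limits, as summarised by the limit of > 15000 nM in this assay, at which 3 of the 3 values shown sit. Compound 4 `C/C=C1/[C@H](O[C@@H]2O[C@H](CO)[C@@H](O)[C@H](O)[C@H]2O)OC=C(C(=O)OC)[C@H]1CC(=O)OCCCC` has not yet been measured in this assay. It differs from compound 2 by propyl in place of 2,3-dihydro-1,4-benzodioxin-6-yl on a saturated chain carbon bound to an oxygen next to a carbonyl group. Within the data shown here, the only single-point step among the measured compounds, a step that the two limits leave unreadable from compound 1 to compound 3, concerns the same ester chain, where isopropyl stands in place of 1-methylethenyl on a saturated chain carbon, two bonds along the chain from an oxygen next to a carbonyl group; its size is not readable because both ends are limits. Nothing measured therefore indicates that an alkyl chain on this ester yields a readable value. The expected step in this assay is a step that the limit leaves unreadable from compound 2 to compound 4, most likely again leaving only a limit. Compound 4 is expected to show about 25000 nM, within 8000 nM to 80000 nM.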

Compound 4, half-maximal inhibitory concentration: > 15000 nM
Compound 4 gave a limit, no number; the forecaster's own chance of this, stated with the estimate: 85%; the middle value does not contradict the limit.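

In this assay compound 4 gives > 15000 nM, a limit and not a number. Among these compounds, compound 2 also gives only a limit, so no step between compound 2 and compound 4 can be read. The compounds shown leave open whether any ester chain on the shared core gives a readable value: the limit of > 15000 nM in this assay, at which 4 of the 4 values shown sit.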